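A Second Chloro on the Shared Core, Measured and Expected

This account rests on a few compounds, and the source may have more. Where it says the series, first, only, none or still open, it means among the compounds named here.

Compound 1 `CCCCCC(CCO)n1cnc2c(N)ncnc21` and compound 2 `CCCCCC(CCO)n1cnc2c(N)nc(Cl)nc21` share one core; compound 3 `CCCCCCCCCC(CCO)n1cnc2c(Cl)ncnc21` and the unmeasured compound 4 `CCCCCCCCCC(CCO)n1cnc2c(Cl)nc(Cl)nc21` share another, and the difference between the two cores is not broken down here. In a functional assay on SW480 cells (Homo sapiens) for antiproliferative activity, read by MTT assay, with a stated time of 48 h (a higher number here means a weaker inhibitor, a lower number a stronger inhibitor), compound 1 gives only a limit of the assay, > 50000 nM. Compound 2 likewise gives a limit, > 50000 nM. The step that the two limits leave unreadable from compound 1 to compound 2 is therefore unreadable, owing to the limit of > 50000 nM in this assay, at which 2 of the 3 values shown sit. Going by the values given here, compound 3 is the only compound with a number, giving 1150 nM. Compound 4 differs from compound 3 by chloro in place of hydrogen on an aromatic carbon, the same kind of change as chloro in place of hydrogen on an aromatic carbon, though the chloro now sits meta to a chloro group rather than meta to an amino group. Because a step that the two limits leave unreadable from compound 1 to compound 2 gives no size, the expected step is a 1.0-fold higher number from compound 3 to compound 4 (0.02 log units; within the scatter), kept small. Compound 4 is estimated at 1200 nM, within 350 nM to 4500 nM.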

Compound 4, half-maximal inhibitory concentration: 36300 nM
Compound 4: the middle estimate sits 30-fold (1.48 log units) below what was measured; the whole stated range lies below it.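

In this assay, chloro in place of hydrogen on an aromatic carbon gives a 32-fold higher number from compound 3 to compound 4 (1.50 log units; beyond the scatter), so on this core the change leaves a much weaker inhibitor. The same change on the core of compound 1 cannot be read, because both compounds on that core give only a limit of the assay: the limit of > 50000 nM in this assay, at which 2 of the 4 values shown sit. The step is therefore readable on one core only, and it does not show whether the change carries the same size from one core to the other.

Going by these compounds, whether a longer chain on the core of compound 1 would give readable values, and so a readable step, remains open. Also open, on these data alone, is how a bromo or methoxy group, between two ring nitrogen atoms, would compare with chloro.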